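This account rests on a few compounds, and the source may have more. Where it says the series, first, only, none or still open, it means among the compounds named here.

Compound 1 `Cn1c(-c2ccccc2)cnc1NC(=O)c1ccc(F)cc1`: > 100000 nM (a limit)
Compound 2 `Cn1c(-c2ccccc2Cl)cnc1NC(=O)c1ccc(F)cc1`: > 50000 nM (a limit)
Compound 3 `Cc1ccc(-c2cnc(NC(=O)c3ccc(F)cc3)n2C)cc1`: 60000 nM

Going by the values given here, in a toxicity assay on THP-1 cells (Homo sapiens) for inhibition (on this read-out lower numbers stand for higher toxicity in this test and higher numbers for lower toxicity in this test), compound 3 gives 60000 nM, the only true number of the three. What compound 1 and compound 2 show are limits of the assay. Compound 4 `Cn1c(-c2ccc(F)cc2)cnc1NC(=O)c1ccc(F)cc1` follows from compound 3 by fluoro in place of methyl on an aromatic carbon, para to a large group. Among the compounds with values here, the one readable step at this substituent is an at least 1.6-fold lower number from compound 1 to compound 3 (0.22 log units; that floor lies within the scatter). Neither a step that the two limits leave unreadable from compound 1 to compound 2 nor a step that the limit leaves unreadable from compound 2 to compound 3 gives a size. No step beyond the scatter is therefore expected, and the estimated change is a 1.2-fold higher number from compound 3 to compound 4 (0.07 log units; within the scatter). Compound 4 is expected at 70000 nM. The estimated range for compound 4 runs from 35000 nM to 130000 nM.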

Compound 4, half-maximal cytotoxic concentration: > 100000 nM
Compound 4: no number, only a limit; the forecaster's own chance of this, stated with the estimate: 50%; at least 1.4-fold (0.15 log units) between middle value and limit.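

Compound 4 gives > 100000 nM in this assay, which is a limit and not a number. Fluoro in place of methyl at this position gives an at least 1.6-fold higher number from compound 3 to compound 4 (0.22 log units; that floor lies within the scatter), so the 4-fluorophenyl and 4-methylphenyl compounds are not shown to differ beyond the scatter. The steps from compound 1 and compound 2 to compound 4 cannot be read, and compound 4 shares its limit with compound 1: the limit of > 100000 nM in this assay, at which 2 of the 4 values shown sit.

From the compounds shown here alone, how far the true value of compound 4 lies from that of compound 3 stays open. So does what an amine or a carboxylic acid on this carbon would give in this assay.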